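A few compounds are considered here, and "the series" means these few. Any claim that something is new, unique, unknown or untested is made for them only; others in the source may bear on it.

Measured in a functional assay on NTUB1 cells (Homo sapiens) for cytotoxicity, read by MTT assay, with a stated time of 72 h; on this read-out higher numbers stand for weaker inhibition and lower numbers for stronger inhibition:
Compound 1 `CCCOC(=O)c1ccc(/C=C/C(=O)c2cc(OC)ccc2OC)cc1`: 6010 nM
Compound 2 `COc1ccc(OC)c(C(=O)/C=C/c2ccc(C(=O)OCc3ccccc3)cc2)c1`: 13300 nM
Compound 3 `CNC(=O)c1ccc(/C=C/C(=O)c2cc(OC)ccc2OC)cc1`: 2200 nM

Of the three, compound 2 gives the highest number, 13300 nM. Compound 4 `COc1ccc(OC)c(C(=O)/C=C/c2ccc(C(=O)NC(C)C)cc2)c1` departs from it with isopropylamino in place of benzyloxy on a carbonyl carbon. Going by the values given here, the closest precedent is methylamino in the same place, a 6.0-fold lower number from compound 2 to compound 3 (0.78 log units; beyond the scatter). Replacing propoxy there with methylamino gave a 2.7-fold lower number from compound 1 to compound 3 (0.44 log units; beyond the scatter), while the two oxygen-linked groups differ by a 2.2-fold higher number from compound 1 to compound 2 (0.34 log units; beyond the scatter). Isopropylamino itself has not been measured, so a step in the same direction as that to compound 3, perhaps somewhat smaller, is expected. The expected step in this assay is a 4.4-fold lower number from compound 2 to compound 4 (0.65 log units; beyond the scatter). For compound 4 the estimated value is 3000 nM, with an expected range of 1200 nM to 7500 nM.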

Compound 4, half-maximal inhibitory concentration: 1970 nM
Estimate against measurement, compound 4: 1.5-fold (0.18 log units) above; low and high end bracket the measured number.
By their numbers in this assay, from the lowest: compounds 4 and 3 (each within the scatter of the next); then compound 1; then compound 2.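

In this assay, a second amide now stands well apart from both esters: isopropylamino on the carbonyl carbon gives the steps (a 6.8-fold lower number from compound 2 to compound 4 (0.83 log units; beyond the scatter)) and (a 3.1-fold lower number from compound 1 to compound 4 (0.48 log units; beyond the scatter)). Isopropyl in place of methyl on the amide-type nitrogen, a change the earlier compounds could not show, leaves the two amides indistinguishable (a 1.1-fold lower number from compound 3 to compound 4 (0.05 log units; within the scatter)). No evidence here accounts for these differences. The compounds shown leave open how dimethylamino, which has no amide hydrogen, or a free carboxylic acid would compare at this carbonyl carbon. They also leave open whether a longer chain on the nitrogen would give a similar number.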